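Compound 3 to compound 4: an iodinated chain end

The compounds below may be only part of what the source reports. "The series", "measured", "known", "first", "only" and "open" are said of these compounds alone.

In an ADME assay on cells (Peritoneal macrophage cell, Mus musculus) for cytotoxicity, read by MTT assay, with a stated time of 72 h (a lower number here means that less compound is tolerated, a higher number that more compound is tolerated), compound 3 `CCOC(=O)c1cn(CCCCCCCCCOS(C)(=O)=O)nn1` gives 983000 nM, the highest of the three numbers and beyond the scatter from the other two. Compound 1 `CS(=O)(=O)OCCCCCCCCCCCCn1cc(CCCOS(C)(=O)=O)nn1` gives 156000 nM, and compound 2 `CS(=O)(=O)OCCCCCCCCCCCCn1cc(CCCO)nn1` gives 163000 nM.

Compound 4 `CCOC(=O)c1cn(CCCCCCCCCCCCI)nn1` carries 3-iodopropyl in place of (methylsulfonyl)oxy on a saturated chain carbon, nine bonds along the chain from an aromatic nitrogen. Within the data shown here, the only measured step, a 1.0-fold higher number from compound 1 to compound 2 (0.02 log units; within the scatter), also removes a methylsulfonyl group, but it puts hydrogen in its place and stays within the scatter. Among the measured compounds shown here, it is a different exchange and offers weak guidance, and no measured pair shows 3-iodopropyl entering.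

With compound 3 at the top of so small a set, a move toward the lower numbers seems likelier than a further rise. The expected change in this assay is a 3.3-fold lower number from compound 3 to compound 4 (0.52 log units; beyond the scatter), an estimate that carries wide uncertainty. For compound 4 the estimated value is 300000 nM, with an expected range of 80000 nM to 1000000 nM.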

Compound 4, half-maximal cytotoxic concentration: 93400 nM
The estimate for compound 4 lay 3.2-fold (0.51 log units) above the measured number, within the range that was stated.
By their numbers in this assay, from the lowest: compounds 4, 1 and 2 (each within the scatter of the next); then compound 3.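

In this assay, the chain end of this series proves sensitive to exchange: 3-iodopropyl in place of (methylsulfonyl)oxy on a saturated chain carbon, nine bonds along the chain from an aromatic nitrogen, gives an 11-fold lower number from compound 3 to compound 4 (1.02 log units; beyond the scatter), a large step. The only earlier step, a 1.0-fold higher number from compound 1 to compound 2 (0.02 log units; within the scatter), replaced methylsulfonyl with hydrogen on an oxygen and stayed within the scatter, so loss of a methylsulfonyl group does not by itself bring a large step in the compounds shown. No measurement at hand bears on the cause of this fall.

This single pair changes the end group and the chain length together, so it cannot separate the iodine from the added carbons. Going by these compounds, how an amine or a carboxylic acid at this chain end would read in this assay remains open.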